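The compounds below may be only part of what the source reports. "The series", "measured", "known", "first", "only" and "open" are said of these compounds alone.

In a functional assay on K562 cells (Homo sapiens) for inhibition, read by fluorescence, with a stated time of 72 h (on this read-out higher numbers stand for weaker inhibition of growth and lower numbers for stronger inhibition of growth), compound 1 `COc1cc(Nc2nc(N[C@H]3CC[C@H](N)CC3)nc3c2ncn3CCC(C)C)cc(OC)c1` gives 2500 nM and compound 2 `CC(C)CCn1cnc2c(Nc3cccc(Cl)c3)nc(N[C@H]3CC[C@H](N)CC3)nc21` gives 1500 nM. Within the data shown here, these are the only two numbers so far, and they lie within the scatter of each other, so compound 1 sits level with its one neighbour. Compound 3 `CCCCn1cnc2c(Nc3cc(OC)cc(OC)c3)nc(N[C@H]3CC[C@H](N)CC3)nc21` has yet to be measured. It differs from compound 1 only in the chain, isopentyl to butyl, with hydrogen in place of methyl on a saturated chain carbon bound to two saturated chain carbons. Among the measured compounds shown here, the one measured step, a 1.7-fold lower number from compound 1 to compound 2 (0.22 log units; within the scatter), is 3-chlorophenyl in place of 3,5-dimethoxyphenyl on a nitrogen on an aromatic ring, so no measured step touches the chain. No shift beyond the scatter is therefore expected in this assay, leaving compound 3 expected close to compound 1 at 2500 nM. The expected change is no change at the digits printed from compound 1 to compound 3 (within the scatter). For compound 3 the estimated value is 2500 nM, with an expected range from 1100 nM to 5500 nM.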

Compound 3, concentration for 50% growth inhibition: 2400 nM
The estimate for compound 3 lay 1.0-fold (0.02 log units) above the measured number; the range from low to high includes it.
By their numbers in this assay, from the lowest: compounds 2, 3 and 1 (each within the scatter of the next).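

Swapping isopentyl for butyl while keeping the 3,5-dimethoxyphenyl group gives a 1.0-fold lower number from compound 1 to compound 3 (0.02 log units; within the scatter) in this assay, and this is the first reading at the chain. The earlier pair spoke only about the group on the nitrogen, whereas this pair shows that hydrogen in place of methyl, on a saturated chain carbon bound to two saturated chain carbons, leaves isopentyl and butyl indistinguishable on this read-out. No measurement here offers an explanation for this result.

The compounds shown leave open whether a much longer chain such as octyl, or a chain ending in an amine or a carboxylic acid, would leave the number just as steady. They also leave open whether butyl would read the same alongside the 3-chlorophenyl group of compound 2.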